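This account rests on a few compounds, and the source may have more. Where it says the series, first, only, none or still open, it means among the compounds named here.

Compound 1, `C=CC1=C(C(=O)NCc2ccc(C)cc2)C(c2ccc(F)cc2)OC1`, is the starting point of this account. In a functional assay on A549 cells (Homo sapiens) for cytotoxicity, read by MTT assay, with a stated time of 24 h (on this read-out lower numbers stand for stronger inhibition and higher numbers for weaker inhibition), compound 1 gives > 100000 nM, which is a limit of the assay rather than a number. Two related compounds have been measured in the same way. Compound 2, `C=CC1=C(C(=O)Nc2ccc(C)cc2)C(c2ccc(F)cc2)OC1`, gives > 100000 nM in this assay, again a limit. Compound 3, `C=CC1=C(C(=O)NCCCCC)C(c2ccc(F)cc2)OC1`, gives > 100000 nM in this assay, also a limit. Because all three sit at the limit of > 100000 nM in this assay, at which 3 of the 3 values shown sit, the steps between them cannot be read: a step that the two limits leave unreadable from compound 1 to compound 2, a step that the two limits leave unreadable from compound 1 to compound 3 and a step that the two limits leave unreadable from compound 2 to compound 3 each remain of unknown size. Compound 1 therefore stands at the limit together with the two others, with no ordering among them.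

Compound 4, `C=CC1=C(C(=O)NCc2ccc(C)cc2)C(c2ccc(OC)cc2)OC1`, is not yet measured. It differs from compound 1 by methoxy in place of fluoro on an aromatic carbon. Among the compounds with values here, none of the measured steps touches this part of the shared core; all three concern the substituent on the amide-type nitrogen, and all three are unreadable. Within the data shown here, nothing among the measured compounds therefore gives a direction or size for this change. The expectation is that compound 4 stays where compound 1 stands, so the step that the limit leaves unreadable from compound 1 to compound 4 is expected to be none beyond the scatter. Compound 4 is thus estimated at 150000 nM, within a range from 50000 nM to 500000 nM, most likely reported once more as a limit in this assay.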

Compound 4, half-maximal inhibitory concentration: > 100000 nM
Compound 4: no number, only a limit; the forecaster's own chance of this, stated with the estimate: 85%; the middle value is on the limit's open side.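

In this assay compound 4 gives > 100000 nM, which is again a limit and not a number. Within the data shown here, compound 1 and compound 4 therefore yield no new readable step, and the change from fluoro to methoxy has no size: the limit of > 100000 nM in this assay, at which 4 of the 4 values shown sit. The compounds shown leave open whether any of the four differ in cytotoxicity, and what change would give a measurable value.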